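A few compounds are considered here, and "the series" means these few. Any claim that something is new, unique, unknown or untested is made for them only; others in the source may bear on it.

Compound 2 `COc1cc(Cn2cc(CNC(=O)c3ccc([N+](=O)[O-])o3)nn2)ccc1F` has been tested in an ADME assay on MRC5 cells (Homo sapiens) for cytotoxicity (a lower number here means a stronger inhibitor, a higher number a weaker inhibitor), where compound 2 gives 155000 nM. Among the measured compounds shown here, only one other compound has a number there: compound 1 `COc1ccc(Cn2cc(CNC(=O)c3ccc([N+](=O)[O-])o3)nn2)cc1O`, which in this assay gives 189000 nM. The two differ only in the ring attached to the saturated chain carbon bound to an aromatic nitrogen, and the step of a 1.2-fold lower number from compound 1 to compound 2 (0.09 log units; within the scatter) is within the scatter, so compound 2 and compound 1 sit side by side, with no real gap between them. Compound 3 `O=C(NCc1cn(Cc2cccc([N+](=O)[O-])c2)nn1)c1ccc([N+](=O)[O-])o1` alters this same position once more: 3-nitrophenyl in place of 4-fluoro-3-methoxyphenyl on a saturated chain carbon bound to an aromatic nitrogen. For the measured compounds named here, the single step that bears on this change, a 1.2-fold lower number from compound 1 to compound 2 (0.09 log units; within the scatter), shows that exchanging the ring at this position left the read-out in this assay essentially unchanged, so no shift beyond the scatter is expected, although one precedent makes the expectation loose. Compound 3 is therefore estimated at 150000 nM, between 60000 nM and 400000 nM, a step of a 1.0-fold lower number from compound 2 to compound 3 (0.01 log units; within the scatter) that is expected to stay within the scatter.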

Compound 3, half-maximal inhibitory concentration: 199000 nM
Compound 3: middle estimate off by 1.3-fold (0.12 log units), on the low side; measured number inside the range.
By their numbers in this assay, from the lowest: compounds 2, 1 and 3 (each within the scatter of the next).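

In this assay, 3-nitrophenyl in place of 4-fluoro-3-methoxyphenyl gives a 1.3-fold higher number from compound 2 to compound 3 (0.11 log units; within the scatter), and 3-nitrophenyl in place of 3-hydroxy-4-methoxyphenyl gives a 1.1-fold higher number from compound 1 to compound 3 (0.02 log units; within the scatter). The earlier pair only exchanged groups on rings that both carried a methoxy group, whereas this ring has no methoxy group and carries a nitro group instead, and the read-out still stays within the scatter. All three rings at this position therefore read alike, and no information at hand gives a reason for this.

Going by these compounds, all three compounds keep a six-membered aromatic ring of carbon at this position, so it remains open whether an amine or a carboxylic acid on that ring, or a longer chain in its place, would move the number beyond the scatter. Changes elsewhere on the shared core also remain open, since all three compounds differ only here.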